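Benzyl in Place of Methyl on the Bromo Core

This account rests on a few compounds, and the source may have more. Where it says the series, first, only, none or still open, it means among the compounds named here.

Compound 3, `CN1C(=O)/C(=C2\S/C(=N/c3ccc(S(N)(=O)=O)cc3)NC2=O)c2cc(Br)ccc21`, was run in a functional assay on Caco-2 cells (Homo sapiens) for antiproliferative activity, read by MTT assay; a lower number here means a stronger inhibitor, a higher number a weaker inhibitor. In this assay compound 3 gives 13200 nM, the lowest of the two numbers shown, and it lies within the scatter of compound 2, `NS(=O)(=O)c1ccc(/N=C2\NC(=O)/C(=C3/C(=O)N(Cc4ccccc4)c4ccc(Cl)cc43)S2)cc1`, which in this assay gives 13700 nM. Compound 1, `NS(=O)(=O)c1ccc(/N=C2\NC(=O)/C(=C3/C(=O)N(Cc4ccccc4)c4ccccc43)S2)cc1`, returns only a limit in this assay, > 200000 nM, which is the limit of > 200000 nM in this assay, at which 1 of the 3 values shown sits. Among the measured compounds shown here, the single measured step, an at least 14-fold lower number from compound 1 to compound 2 (1.16 log units; beyond the scatter), is large, but it concerns a change on an aromatic carbon rather than the change considered next.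

Compound 4, `NS(=O)(=O)c1ccc(/N=C2\NC(=O)/C(=C3/C(=O)N(Cc4ccccc4)c4ccc(Br)cc43)S2)cc1`, differs from compound 3 by phenyl in place of hydrogen on a saturated chain carbon bound to an amide-type nitrogen in a ring; cut one bond further out, the same difference reads methyl to benzyl. For the measured compounds named here, no measured step covers this change. Compound 2 already carries the benzyl group, and its value and that of compound 3 sit within the scatter of each other. One therefore expects no step beyond the scatter, a 1.1-fold lower number from compound 3 to compound 4 (0.04 log units; within the scatter). Compound 4 is estimated at 12000 nM, between 5000 nM and 30000 nM.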

Compound 4, half-maximal inhibitory concentration: 57800 nM
The estimate for compound 4 lay 4.8-fold (0.68 log units) below the measured number; the measured number lies above the stated range.
By their numbers in this assay, from the lowest: compounds 3 and 2 (each within the scatter of the next); then compound 4. At a limit, above all of these: compound 1.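

On the bromo core, the change from methyl to benzyl is not neutral in this assay: phenyl in place of hydrogen on a saturated chain carbon bound to an amide-type nitrogen in a ring gives a 4.4-fold higher number from compound 3 to compound 4 (0.64 log units; beyond the scatter). With benzyl held constant, bromo in place of chloro on an aromatic carbon gives a 4.2-fold higher number from compound 2 to compound 4 (0.63 log units; beyond the scatter), so the two halogens are not interchangeable in this series. Adding the halogen to the core that lacks one still gives an at least 3.4-fold lower number from compound 1 to compound 4 (0.53 log units; beyond the scatter), but this step rests on a limit, so its true size stays open: the limit of > 200000 nM in this assay, at which 1 of the 4 values shown sits.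

The compounds shown pair methyl and benzyl on the bromo core only, so whether the change carries over to the chloro core remains open. They also leave open how an amine or a carboxylic acid on the benzyl phenyl, or a longer chain in place of benzyl, would read in this assay.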